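Carbamate series: cytotoxicity notes on compounds 1 to 4

The compounds below may be only part of what the source reports. "The series", "measured", "known", "first", "only" and "open" are said of these compounds alone.

Measured in an ADME assay on HepG2 cells (Homo sapiens) for cytotoxicity, read by MTT assay; a lower number here means a stronger inhibitor, a higher number a weaker inhibitor:
- compound 1, `O=C(Nc1ccccc1)Oc1ccc(Cl)cc1C(=O)Nc1ccc(F)cc1`: gives > 20000 nM, which is a limit of the assay and not a number.
- compound 2, `O=C(NC1CCCCC1)Oc1ccc(Cl)cc1C(=O)Nc1ccc(F)cc1`: gives 21200 nM.
- compound 3, `O=C(Nc1ccccc1)Oc1ccc(Cl)cc1C(=O)Nc1ccc(C(F)(F)F)cc1`: gives 9800 nM.

The change from compound 1 to compound 2 is cyclohexyl in place of phenyl on an amide-type nitrogen. Its size in this assay is a step that the limit leaves unreadable from compound 1 to compound 2, because the limit of > 20000 nM in this assay, at which 1 of the 3 values shown sits, hides the starting point. The change from compound 1 to compound 3 is trifluoromethyl in place of fluoro on an aromatic carbon; it gives an at least 2.0-fold lower number from compound 1 to compound 3 (0.30 log units; that floor lies within the scatter). Among the compounds with values here, compound 2 and compound 3 have no step recorded between them; their two numbers show compound 3 with the lower value, the gap being beyond the usual scatter.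

Compound 4, `O=C(NC1CCCCC1)Oc1ccc(Cl)cc1C(=O)Nc1ccc(C(F)(F)F)cc1`, is not yet measured. It differs from compound 3 by cyclohexyl in place of phenyl on an amide-type nitrogen. This is the same change as from compound 1 to compound 2, made on a core that differs by the trifluoromethyl in place of fluoro already described; the place is the same in both cases.

Within the data shown here, for compound 4 the change is expected to leave the number roughly where compound 3 sits, a 1.1-fold higher number from compound 3 to compound 4 (0.05 log units; within the scatter), since the one measured instance of this change, a step that the limit leaves unreadable from compound 1 to compound 2, gives no readable size, so the expectation rests on compound 3 alone, 9800 nM, with a wide margin. Compound 4 is therefore estimated at 11000 nM, between 4000 nM and 28000 nM.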

Compound 4, half-maximal inhibitory concentration: > 125000 nM
Compound 4: only a limit was reported (the forecaster's own chance of this, stated with the estimate: 30%); middle value at least 11-fold (1.05 log units) from the limit.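

In this assay, cyclohexyl in place of phenyl on the amide-type nitrogen gives an at least 12-fold higher number from compound 3 to compound 4 (1.10 log units; beyond the scatter), and trifluoromethyl in place of fluoro on an aromatic carbon, with cyclohexyl on that nitrogen, gives an at least 5.8-fold higher number from compound 2 to compound 4 (0.77 log units; beyond the scatter). The trifluoromethyl change therefore does not carry from the core of compound 1 to the core of compound 2 as one fixed step, and the two steps run in opposite directions: the same change on two cores in this assay, an at least 2.0-fold lower number (0.30 log units; that floor lies within the scatter) from compound 1 to compound 3 and an at least 5.8-fold higher number (0.77 log units; beyond the scatter) from compound 2 to compound 4, at least 12-fold (1.08 log units) apart, beyond the scatter of two such steps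

The readings for compound 1 and compound 4 are limits of the assay and not numbers, so the true sizes of these steps are not shown, the step from compound 1 to compound 2 cannot be read, and it remains unknown how far the cyclohexyl change differs between the two cores: the limit of > 125000 nM in this assay, at which 1 of the 4 values shown sits.

Open, going by these compounds, is whether the large step to compound 4 belongs only to the pairing of cyclohexyl with trifluoromethyl, or also appears with a benzyl group or a longer chain such as hexyl on the amide-type nitrogen. Equally open, on these data alone, is how a nitrile, a chlorine or a carboxylic acid in place of trifluoromethyl on that aromatic carbon would read alongside cyclohexyl.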